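Chalcone series: aryl ketone swap, cytotoxicity read-out

The source may hold more compounds than are shown below. What is called first, only, known or untested is meant among the compounds shown, and "the series" means these compounds.

Measured so far:
compound 1 `COc1ccc(C(=O)/C=C/c2cccc(OCc3ccccc3)c2)cc1` 79800 nM
compound 2 `O=C(/C=C/c1cccc(OCc2ccccc2)c1)c1ccc(Cl)cc1Cl` 24900 nM
compound 3 `O=C(/C=C/c1cccc(OCc2ccccc2)c1)c1ccc([N+](=O)[O-])cc1` 59300 nM

All three share the same benzyloxy-styryl enone; only the ring on the carbonyl carbon varies. In an ADME assay on HEK293 cells (Homo sapiens) for cytotoxicity, read by MTT assay, with a stated time of 68 h (on this read-out higher numbers stand for weaker inhibition and lower numbers for stronger inhibition), compound 3 gives 59300 nM, the second highest of the three numbers. Its gap to compound 1 lies within the scatter, so no order between them is claimed. Its gap to compound 2 is beyond the scatter: a 2.4-fold higher number from compound 2 to compound 3 (0.38 log units; beyond the scatter).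

Compound 4 `O=C(/C=C/c1cccc(OCc2ccccc2)c1)c1ccc(Cl)c(Cl)c1Cl` has not been measured. It differs from compound 3 in one place: 2,3,4-trichlorophenyl in place of 4-nitrophenyl on a carbonyl carbon.

For the measured compounds named here, two measured steps bear on this. First, a 2.4-fold higher number from compound 2 to compound 3 (0.38 log units; beyond the scatter), which is the reverse of the present direction (a chlorinated ring replacing the nitro-bearing ring). Second, a 3.2-fold lower number from compound 1 to compound 2 (0.51 log units; beyond the scatter), where a chlorinated ring again gave the lower number. Both point the same way, and a trichlorophenyl is close in kind to the dichlorophenyl of compound 2, so a modest drop in the number, beyond the scatter, is expected for compound 4 in this assay: a 2.4-fold lower number from compound 3 to compound 4 (0.38 log units; beyond the scatter). Compound 4 is therefore estimated at 25000 nM in this assay, with a range from 10000 nM to 60000 nM, roughly the region where compound 2 already sits. Whether the third chlorine moves the number further is not told by anything measured so far.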

Compound 4, half-maximal inhibitory concentration: 2400 nM
Compound 4: middle estimate off by 10-fold (1.02 log units), on the high side, outside the stated range (below it).
By their numbers in this assay, from the lowest: compound 4; then compound 2; then compounds 3 and 1 (each within the scatter of the next).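

In this assay, the ring on the carbonyl carbon moves the number much further than the three earlier compounds showed: their steps were modest at most, whereas the 2,3,4-trichlorophenyl gives a 25-fold lower number from compound 3 to compound 4 (1.39 log units; beyond the scatter) and a 33-fold lower number from compound 1 to compound 4 (1.52 log units; beyond the scatter). For the compounds shown here, the new finding is that the series does not level off at the 2,4-dichlorophenyl of compound 2: chloro in place of hydrogen on an aromatic carbon gives a 10-fold lower number from compound 2 to compound 4 (1.02 log units; beyond the scatter), larger than any step among the earlier compounds, so a chlorinated ring on the carbonyl carbon is not a single class on this read-out. Nothing measured here accounts for the size of this drop.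

The compounds shown leave open whether the drop follows from the number of chlorines or from their arrangement, a question that a 3,4-dichlorophenyl or a 2,4,6-trichlorophenyl on the same carbonyl carbon would address. Also open, going by these compounds, is whether the low number depends on chlorine itself or would persist with bromo or trifluoromethyl groups on that ring, or with an amine on it.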